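The source may report more compounds than this note shows. Statements on the series, on what has been measured and on what is new or still open speak of the compounds shown alone.

Of the compounds shown here, three have been tested in an ADME assay on BHK-21 cells (Mesocricetus auratus) for cytotoxicity, read by MTT assay (a higher number here means that more compound is tolerated, a lower number that less compound is tolerated), and one more waits its turn. Compound 1 `C/C(=N\NC(N)=S)c1ccc2[nH]c(-c3ccc(Cl)cc3)nc2c1` carries a chloro group on its outer ring. In this assay compound 1 gives > 100000 nM, which is a limit of the assay and not a number. Compound 2 `C/C(=N\NC(N)=S)c1ccc2[nH]c(-c3ccc(C(F)(F)F)cc3)nc2c1` differs from compound 1 in one place: trifluoromethyl in place of chloro on an aromatic carbon. In this assay compound 2 gives 5000 nM. The step between them is an at least 20-fold lower number from compound 1 to compound 2 (1.30 log units; beyond the scatter), and its size is known only as a lower bound because the limit of > 100000 nM in this assay, at which 2 of the 3 values shown sit, is where compound 1 sits.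

Compound 3 `C/C(=N\NC(N)=O)c1ccc2c(c1)nc(-c1ccc(Cl)cc1)n2C1CCCCC1` is built on another core; the difference between the core of compound 3 and the core of compound 1 is not broken down here. In this assay compound 3 gives > 100000 nM, again a limit of the assay rather than a number. Compound 4 `C/C(=N\NC(N)=O)c1ccc2c(c1)nc(-c1ccc(C(F)(F)F)cc1)n2C1CCCCC1` has not yet been measured. It differs from compound 3 by trifluoromethyl in place of chloro on an aromatic carbon, and the place of this change reads the same word for word as the change from compound 1 to compound 2, so it is the same change set on a different core.

Resting on the measured step of an at least 20-fold lower number from compound 1 to compound 2 (1.30 log units; beyond the scatter), the expected step is an at least 8.3-fold lower number from compound 3 to compound 4 (0.92 log units; beyond the scatter), with wide uncertainty since the cores differ and the earlier step is bounded only on one side. Compound 4 is therefore estimated at 12000 nM, with a likely range from 3000 nM to 100000 nM.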

Compound 4, half-maximal cytotoxic concentration: > 100000 nM
Compound 4 ended at the assay's limit; the forecaster's own chance of this, stated with the estimate: 35%; at least 8.3-fold (0.92 log units) between middle value and limit.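

Compound 3 and compound 4 both end at a limit of this assay rather than at a number, so the step between them cannot be read: the limit of > 100000 nM in this assay, at which 3 of the 4 values shown sit.

The compounds shown leave open whether trifluoromethyl in place of chloro lowers the tolerated amount on the core of compound 3 as it does on the core of compound 1.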